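The source may hold more compounds than are shown below. What is called first, only, known or untested is meant among the compounds shown, and "the series" means these compounds.

Of the compounds shown here, two have numbers so far in a functional assay on HCT-116 cells (Homo sapiens) for inhibition, read by MTT assay, with a stated time of 72 h; a higher number here means a weaker inhibitor, a lower number a stronger inhibitor: compound 1 (`CC1=NN(c2ccccc2)C(=O)[C@@]12C(=O)C=CC[C@H]2c1cccc(C)c1`) gives 5820 nM and compound 2 (`CC1=NN(c2ccccc2)C(=O)[C@]12C(=O)C=CC[C@H]2c1ccccc1`) gives 5300 nM, values within the scatter of each other. Compound 3 (`CC1=NN(c2ccccc2)C(=O)[C@@]12C(=O)C=CC[C@H]2c1ccccc1`) has the same atoms and bonds as compound 2 and differs only in configuration as drawn (the two compounds have the same atoms and bonds and differ only in configuration as drawn: 1 of 2 stereo elements differ; a stereocentre at a saturated ring carbon is drawn S in compound 2 and R in compound 3): a stereocentre at a saturated ring carbon is drawn S in compound 2 and R in compound 3. Among the compounds with values here, no measured pair shows what such a change does in this assay, so no step beyond the scatter is expected, in either direction, and the range stays wide. The estimated 1.1-fold higher number from compound 2 to compound 3 (0.05 log units; within the scatter) is small. Compound 3 is expected at 6000 nM, within an estimated range of 2500 nM to 15000 nM.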

Compound 3, half-maximal inhibitory concentration: 4400 nM
For compound 3 the middle estimate is 1.4-fold (0.13 log units) above the measured one, within the range that was stated.
By their numbers in this assay, from the lowest: compounds 3, 2 and 1 (each within the scatter of the next).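

In this assay, the change of configuration at the saturated ring carbon gives a 1.2-fold lower number from compound 2 to compound 3 (0.08 log units; within the scatter), so this stereocentre shows no effect beyond the scatter in this pair. The comparison isolates that single stereocentre, resting on one point: the fact that compounds 2 and 3 differ only in the configuration as drawn. Hydrogen in place of methyl on an aromatic carbon gives a 1.3-fold lower number from compound 1 to compound 3 (0.12 log units; within the scatter), also within the scatter.

As far as these compounds go, the effect of changing the second stereo element remains open. So does whether an amine or a carboxylic acid on that aromatic carbon would shift the number beyond the scatter.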